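The compounds below may be only part of what the source reports. "The series", "measured", "known", "first", "only" and "open" are said of these compounds alone.

Among the compounds with values here, in a functional assay on MDA-MB-468 cells (Homo sapiens) for inhibition, read by MTT assay (a lower number here means a stronger inhibitor of growth, a higher number a weaker inhibitor of growth), compound 2 (`CC1=C(/C=C/C(C)=C/C=C/C(C)=C\C(=O)Nc2ccccc2O)C(C)(C)CCC1n1ccnc1`) gives 3030 nM, the lower of the two numbers so far, while compound 1 (`CC1=C(/C=C/C(C)=C/C=C/C(C)=C\C(=O)Nc2cccc(F)c2)C(C)(C)CCC1n1ccnc1`) gives 6760 nM. Compound 3 (`CC1=C(/C=C/C(C)=C/C=C/C(C)=C\C(=O)NCc2ccc(F)cc2)C(C)(C)CCC1n1ccnc1`) carries 4-fluorobenzyl in place of 2-hydroxyphenyl on an amide-type nitrogen. Within the data shown here, the only measured step at this place, a 2.2-fold lower number from compound 1 to compound 2 (0.35 log units; beyond the scatter), is modest. Neither measured compound carries 4-fluorobenzyl, so that step is a thin guide. A similarly modest change toward a higher number is expected in this assay, an estimated 1.7-fold higher number from compound 2 to compound 3 (0.22 log units; within the scatter). The estimate for compound 3 is 5000 nM, with an expected range of 2000 nM to 12000 nM.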

Compound 3, concentration for 50% growth inhibition: 2450 nM
Compound 3: middle estimate off by 2.0-fold (0.31 log units), on the high side; the range from low to high includes it.
By their numbers in this assay, from the lowest: compounds 3 and 2 (each within the scatter of the next); then compound 1.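

In this assay, the amide-type nitrogen tolerates 4-fluorobenzyl as well as 2-hydroxyphenyl, as a 1.2-fold lower number from compound 2 to compound 3 (0.09 log units; within the scatter) shows, even though 4-fluorobenzyl has 0 hydrogen-bond donors and 0 hydrogen-bond acceptors where 2-hydroxyphenyl has 1 of each. Against 3-fluorophenyl, the same group gives a 2.8-fold lower number from compound 1 to compound 3 (0.44 log units; beyond the scatter), so the two fluorine-bearing groups do differ, though only modestly. Still open, going by these compounds, is how a longer chain such as phenethyl, or an unsubstituted benzyl, would fare at this nitrogen. No evidence given here accounts for these numbers.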